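Replacing the Oxetanyl Amide with a Morpholine Amide

A few compounds are considered here, and "the series" means these few. Any claim that something is new, unique, unknown or untested is made for them only; others in the source may bear on it.

In a functional assay on BXPC-3 cells (Homo sapiens) for inhibition, read by MTT assay, with a stated time of 7 days (a higher number here means a weaker inhibitor, a lower number a stronger inhibitor), compound 3 `CCN(CC)S(=O)(=O)c1ccc(S(=O)(=O)N2CCC[C@@H](C(=O)NC3COC3)C2)cc1` gives 13800 nM, the highest number of the three measured compounds, and so the weakest inhibitor among them. Compound 1 `CCN(CC)S(=O)(=O)c1ccc(S(=O)(=O)N2CCC[C@@H](C(=O)N3CCC(O)CC3)C2)cc1` gives 4710 nM and compound 2 `CCN(CC)S(=O)(=O)c1ccc(S(=O)(=O)N2CCC[C@@H](C(=O)N3CCC(OC)CC3)C2)cc1` gives 1420 nM; the step of a 3.3-fold lower number from compound 1 to compound 2 (0.52 log units; beyond the scatter) comes from a methyl in place of hydrogen on an oxygen on a saturated carbon. The change to compound 4 `CCN(CC)S(=O)(=O)c1ccc(S(=O)(=O)N2CCC[C@@H](C(=O)N3CCOCC3)C2)cc1` is morpholin-4-yl in place of (oxetan-3-yl)amino on a carbonyl carbon. Going by the values given here, two measured steps bear on it, both running the opposite way, from a carbonyl bearing a six-membered ring to the oxetan-3-yl amino group: a 2.9-fold higher number from compound 1 to compound 3 (0.47 log units; beyond the scatter) and a 9.7-fold higher number from compound 2 to compound 3 (0.99 log units; beyond the scatter). Returning to a carbonyl bearing a six-membered ring, a lower number is expected, of size a 4.6-fold lower number from compound 3 to compound 4 (0.66 log units; beyond the scatter), bringing the number close to those seen for compound 1 and compound 2. Compound 4 is therefore estimated at 3000 nM, with a likely range from 1000 nM to 9000 nM.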

Compound 4, half-maximal inhibitory concentration: 790 nM
The estimate for compound 4 lay 3.8-fold (0.58 log units) above the measured number; the whole stated range lies above it.
By their numbers in this assay, from the lowest: compounds 4 and 2 (each within the scatter of the next); then compound 1; then compound 3.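

At this carbonyl carbon, morpholin-4-yl in place of (oxetan-3-yl)amino gives a 17-fold lower number from compound 3 to compound 4 (1.24 log units; beyond the scatter) in this assay and this is the largest step among these compounds. Morpholin-4-yl in place of 4-methoxypiperidin-1-yl gives a 1.8-fold lower number from compound 2 to compound 4 (0.25 log units; within the scatter) and so leaves compound 4 and compound 2 level, whereas morpholin-4-yl in place of 4-hydroxypiperidin-1-yl gives a 6.0-fold lower number from compound 1 to compound 4 (0.78 log units; beyond the scatter) and sets compound 4 clearly apart from compound 1. No measurement here explains these differences.

From the compounds shown here alone, the step to compound 4 removes the amide hydrogen and changes the ring together, so the share of each remains unknown. Also open, going by these compounds, is whether piperazin-1-yl or an open-chain dimethylamino group on this carbonyl carbon would give a number as low as that of compound 4.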